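The source may hold more compounds than are shown below. What is called first, only, known or untested is meant among the compounds shown, and "the series" means these compounds.

In a functional assay on the whole organism for inhibition, with Mus musculus as the target (on this read-out lower numbers stand for an effect already at smaller amounts and higher numbers for an effect only at larger amounts of compound), compound 2 `CN1Cc2c(N)cccc2C(c2ccc(F)cc2)C1` gives 0.25 mg/kg as the lower of two numbers, while compound 1 `CN1Cc2c(N)cccc2C(c2ccc(Cl)cc2)C1` gives 1.1 mg/kg as the higher. Compound 3 `Cc1ccc(C2CN(C)Cc3c(N)cccc32)cc1` differs from compound 2 by methyl in place of fluoro on an aromatic carbon in the form of methyl in place of fluoro on an aromatic carbon, para to a large group. For the measured compounds named here, the one measured step at this place is a 4.4-fold lower number from compound 1 to compound 2 (0.64 log units; beyond the scatter) for fluoro in place of chloro, modest but beyond the scatter, so a similar step toward a higher number is expected in this assay although no methyl compound has been measured. The expected step is a 2.8-fold higher number from compound 2 to compound 3 (0.45 log units; beyond the scatter) in this estimate. Compound 3 is estimated at 0.7 mg/kg with an expected range from 0.2 mg/kg to 2.5 mg/kg overall.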

Compound 3, dose for half-maximal effect: about 1.2 mg/kg
Compound 3: the middle estimate sits 1.7-fold (0.23 log units) below what was measured; low and high end bracket the measured number.
By their numbers in this assay, from the lowest: compound 2; then compounds 1 and 3 (each within the scatter of the next).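

In this assay, methyl in place of fluoro on the aromatic carbon para to a large group gives a 4.8-fold higher number from compound 2 to compound 3 (0.68 log units; beyond the scatter), so fluoro now stands apart from two other groups at this position, not only from chloro. Methyl in place of chloro gives a 1.1-fold higher number from compound 1 to compound 3 (0.04 log units; within the scatter), which leaves compound 1 and compound 3 indistinguishable on this read-out. Nothing available explains why fluoro differs from the other two groups. The compounds shown leave open whether hydrogen, methoxy or trifluoromethyl at this position would give numbers near that of fluoro or near those of chloro and methyl.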